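A few compounds are considered here, and "the series" means these few. Any claim that something is new, unique, unknown or untested is made for them only; others in the source may bear on it.

Measured values in a functional assay on HepG2 cells (Homo sapiens) for antiproliferative activity, read by CCK-8 assay, with a stated time of 72 h (on this read-out higher numbers stand for weaker inhibition and lower numbers for stronger inhibition), are as follows.

compound 1 `COc1cc(C(=O)Nc2ccc(C(=O)/C=C/c3nc(C)c(C)nc3C)cc2)cc(OC)c1OC` gives 4860 nM
compound 2 `COc1cccc(OC)c1C(=O)Nc1ccc(C(=O)/C=C/c2nc(C)c(C)nc2C)cc1` gives 3380 nM
compound 3 `Cc1nc(C)c(/C=C/C(=O)c2ccc(NC(=O)c3ccc(F)cc3)cc2)nc1C` gives 2250 nM

Compound 2 with 3380 nM lies inside the span of these three numbers and within the scatter of both compound 1 and compound 3. The next structure is compound 4 `Cc1nc(C)c(/C=C/C(=O)c2ccc(NC(=O)c3ccc(F)cc3F)cc2)nc1C`, not yet measured. Its difference from compound 2 is 2,4-difluorophenyl in place of 2,6-dimethoxyphenyl on a carbonyl carbon with 2,4-difluorophenyl in place of 2,6-dimethoxyphenyl on a carbonyl carbon.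

Among the measured compounds shown here, the one measured step at this place is a 1.5-fold lower number from compound 2 to compound 3 (0.18 log units; within the scatter) with 4-fluorophenyl in place of 2,6-dimethoxyphenyl on a carbonyl carbon. For the measured compounds named here, a step of that size sets no direction in this assay, and no measurement yet covers 2,4-difluorophenyl, so no shift beyond the scatter is expected. The expected step is a 1.4-fold lower number from compound 2 to compound 4 (0.13 log units; within the scatter) as an estimate resting on that single measured step. Compound 4 is estimated at 2500 nM with an expected range from 1100 nM to 5500 nM in this read-out.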

Compound 4, half-maximal inhibitory concentration: 2990 nM
Compound 4: middle estimate off by 1.2-fold (0.08 log units), on the low side; the range from low to high includes it.
By their numbers in this assay, from the lowest: compounds 3, 4, 2 and 1 (each within the scatter of the next, the first and the last beyond it).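

In this assay, 2,4-difluorophenyl on a carbonyl carbon whose other neighbour is the amide-type nitrogen gives (a 1.1-fold lower number from compound 2 to compound 4 (0.05 log units; within the scatter)), so a second replacement of 2,6-dimethoxyphenyl at this place also stays within the scatter. The series now also holds a direct test of fluoro in place of hydrogen on an aromatic carbon of the 4-fluorophenyl group, and that change gives (a 1.3-fold higher number from compound 3 to compound 4 (0.12 log units; within the scatter)), again without setting a direction. Across 2,6-dimethoxyphenyl, 4-fluorophenyl and 2,4-difluorophenyl, then, no listed step at this place leaves the scatter, an observation that holds for compounds 2, 3 and 4 only.

On these data alone, whether this place tolerates any change in this assay or has simply met groups too alike to separate stays open, since a dimethylamino group, a carboxylic acid or a longer alkyl chain on this phenyl ring could still move the number beyond the scatter. As far as these compounds go, whether chloro or trifluoromethyl would behave as fluoro does is equally open. No available evidence bears on these results.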